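Swapping Pyridine Attachment in a Paw Edema Series

The compounds below may be only part of what the source reports. "The series", "measured", "known", "first", "only" and "open" are said of these compounds alone.

In a functional assay on the whole organism (strain Charles Foster albino) for inhibition, with Rattus norvegicus as the target, read by paw edema, with stated times of 30 min and 3 h, at a dose of 50 mg/kg by the oral route (on this read-out lower numbers stand for less inhibition and higher numbers for more inhibition at the one dose given (going by the name of the read-out)), compound 1 `CN(C)c1ccc(C2CC(c3ccncc3)=NN2)cc1` gives 0%, the lowest of the three numbers measured. Within the data shown here, compound 2 `COc1ccc(OC)c(C2CC(c3ccncc3)=NN2)c1` gives 13% in this assay, and compound 3 `COc1ccc(OC)c(C2CC(c3ccccn3)=NN2c2ccccc2)c1` gives 27%; both differ from compound 1 in more than one place, so they offer no single clean step. Compound 4 `CN(C)c1ccc(C2CC(c3ccccn3)=NN2)cc1` differs from compound 1 by one change: pyridin-2-yl in place of pyridin-4-yl on a carbon with a double bond to nitrogen. Compound 3 also carries pyridin-2-yl, but its other differences leave its value uninformative on this change alone. Compound 4 is therefore expected to give about 10%, in a range from 0% to 28%. The expected step of a number 10 percentage points higher from compound 1 to compound 4 (within the scatter) is small and upward, likely within the usual scatter.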

Compound 4, a percentage reported as inhibition, in the whole organism at one dose (the size of the read-out at that dose, not a potency): 18%
For compound 4 the middle estimate is 8 percentage points below the measured one; low and high end bracket the measured number.
By their numbers in this assay, from the lowest: compound 1; then compounds 2, 4 and 3 (each within the scatter of the next, the first and the last beyond it).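

In this assay, pyridin-2-yl in place of pyridin-4-yl gives a number 18 percentage points higher from compound 1 to compound 4 (beyond the scatter). Among these compounds, with the same atoms joined differently, this shows that the point of attachment of the pyridine at this position can alone change the read-out, which the earlier compounds, differing in more than one place, could not show. No accompanying measurement bears on why this step occurs. Still open, on these data alone, is how pyridin-3-yl or a morpholine would read at this position. Also open, as far as these compounds go, is whether the same swap would give a similar step on the core of compound 2.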